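From 2-Methylphenyl to 3,4-Difluorophenyl on the Amide

The compounds below may be only part of what the source reports. "The series", "measured", "known", "first", "only" and "open" are said of these compounds alone.

In a functional assay on MDA-MB-231 cells (Homo sapiens) for cytotoxicity, read by MTT assay, with a stated time of 72 h (on this read-out higher numbers stand for weaker inhibition and lower numbers for stronger inhibition), compound 3 (`Cc1ccccc1NC(=O)CN1CCN(c2nnc(Cc3ccncc3)c3ccccc23)CC1`) gives 200 nM, the middle of three numbers, between compound 1 (`O=C(CN1CCN(c2nnc(Cc3ccncc3)c3ccccc23)CC1)Nc1ccc(F)c(Cl)c1`) at 4 nM and compound 2 (`O=C(CN1CCN(c2nnc(Cc3ccncc3)c3ccccc23)CC1)Nc1c(F)cccc1F`) at 1900 nM. Compound 4 (`O=C(CN1CCN(c2nnc(Cc3ccncc3)c3ccccc23)CC1)Nc1ccc(F)c(F)c1`) carries 3,4-difluorophenyl in place of 2-methylphenyl on an amide-type nitrogen. The aryl group alone has moved this assay widely, as in the large 480-fold higher number from compound 1 to compound 2 (2.68 log units; beyond the scatter) and the modest 9.5-fold lower number from compound 2 to compound 3 (0.98 log units; beyond the scatter). Most relevant is the large 50-fold higher number from compound 1 to compound 3 (1.70 log units; beyond the scatter), since the group of compound 1 also has two halogens, though no measurement compares them directly. A clear move toward stronger inhibition is therefore expected, with a 10-fold lower number from compound 3 to compound 4 (1.00 log units; beyond the scatter) estimated. For compound 4 the estimated value is 20 nM, within an expected range of 4 nM to 120 nM.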

Compound 4, half-maximal inhibitory concentration: 0.84 nM
For compound 4 the middle estimate is 24-fold (1.38 log units) above the measured one, outside the stated range (below it).
By their numbers in this assay, from the lowest: compound 4; then compound 1; then compound 3; then compound 2.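

In this assay, halogen count alone does not decide the outcome at the amide-type nitrogen: 3,4-difluorophenyl in place of 2,6-difluorophenyl gives a 2300-fold lower number from compound 2 to compound 4 (3.35 log units; beyond the scatter), the widest step in the set, while replacing 2-methylphenyl gives a 240-fold lower number from compound 3 to compound 4 (2.38 log units; beyond the scatter). Chloro is also not required for a low number, since fluoro in place of chloro on an aromatic carbon gives a 4.8-fold lower number from compound 1 to compound 4 (0.68 log units; beyond the scatter), leaving compound 4 the strongest of the four. Nothing available explains these steps.

The compounds shown leave open how an unsubstituted phenyl or a methoxyphenyl group would compare on this nitrogen.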